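Urea to amide at the trifluoromethylphenyl end

The source may report more compounds than this note shows. Statements on the series, on what has been measured and on what is new or still open speak of the compounds shown alone.

Compound 2 `COc1cc(Cl)cc(-c2nn(-c3cccc(NC(=O)Nc4cccc(C(F)(F)F)c4)c3)cc2-c2ccncc2)c1` gives 58% in a functional assay on T47D cells (Homo sapiens) for inhibition, read by sulforhodamine B assay, with a stated time of 48 h, tested at 1 uM (on this read-out higher numbers stand for a weaker effect at the one concentration tested and lower numbers for a stronger effect), the lowest of the two numbers: compound 1 `COc1cc(Cl)cc(-c2nn(-c3cccc(NC(=O)Nc4ccc(Cl)c(Cl)c4)c3)cc2-c2ccncc2)c1` gives 87%. Compound 3 `COc1cc(Cl)cc(-c2nn(-c3cccc(NC(=O)c4cccc(C(F)(F)F)c4)c3)cc2-c2ccncc2)c1` differs from compound 2 by 3-(trifluoromethyl)phenyl in place of (3-(trifluoromethyl)phenyl)amino on a carbonyl carbon. Among the compounds with values here, the one measured step, a number 29 percentage points lower from compound 1 to compound 2 (beyond the scatter), concerns the group on the amide-type nitrogen, not the nitrogen itself, so no step bears directly on this change. Compound 3 is therefore expected to stay near compound 2, with wide uncertainty, at 65% (range 40% to 90%). That estimate means an expected step of a number 7 percentage points higher from compound 2 to compound 3 (within the scatter).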

Compound 3, a percentage reported as activity, at one concentration (the size of the read-out at that concentration, not a potency): 92%
Compound 3: middle estimate off by 27 percentage points, on the low side, and the stated range ends below it.
By their numbers in this assay, from the lowest: compound 2; then compounds 1 and 3 (each within the scatter of the next).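

Removing the amino nitrogen from the carbonyl carbon, with the 3-(trifluoromethyl)phenyl group kept, weakens the effect in this assay, which shows a number 34 percentage points higher from compound 2 to compound 3 (beyond the scatter). The trifluoromethylphenyl group therefore does not carry the effect of compound 2 alone, and with the amide link the read-out shows a number 5 percentage points higher from compound 1 to compound 3 (within the scatter). Nothing at hand explains why this nitrogen matters.

Going by these compounds, whether the nitrogen itself or its hydrogen counts remains open. An N-methyl urea or a methylene link at this carbonyl carbon would help to separate the two.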